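Methoxy step from compound 2 to compound 4

The source may hold more compounds than are shown below. What is called first, only, known or untested is meant among the compounds shown, and "the series" means these compounds.

Within the data shown here, in an ADME assay on Huh-7 cells (Homo sapiens) for cytotoxicity, read by MTT assay, with a stated time of 72 h (on this read-out lower numbers stand for higher toxicity in this test and higher numbers for lower toxicity in this test), compound 2 `C/C(=C\c1c[nH]c2ccccc12)C(=O)Nc1ccc(C(C)(C)C)cc1` gives 17300 nM and compound 3 `COc1cccc2[nH]cc(/C=C(\C)C(=O)Nc3ccc(C(C)(C)C)cc3)c12` gives 34100 nM as the only two numbers so far. The step of a 2.0-fold higher number from compound 2 to compound 3 (0.29 log units; within the scatter) lies within the scatter, so these two compounds cannot be told apart on this read-out. Compound 1 `CC(C)NC(=O)/C=C/c1c[nH]c2ccccc12` gives > 100000 nM in this assay and that entry is a limit of the assay, not a number.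

Compound 4 `COc1ccc2[nH]cc(/C=C(\C)C(=O)Nc3ccc(C(C)(C)C)cc3)c2c1` is still unmeasured. Its difference from compound 2 is methoxy in place of hydrogen on an aromatic carbon and the change is methoxy in place of hydrogen on an aromatic carbon. Among the measured compounds shown here, only one measured step bears on it: compound 3 carries the same replacement at a different aromatic carbon, and its step of a 2.0-fold higher number from compound 2 to compound 3 (0.29 log units; within the scatter) stays within the scatter. This is a single precedent, and the position in compound 4 has no measurement of its own. No step beyond the scatter is therefore expected in this assay for this change. The expected change is a 1.4-fold higher number from compound 2 to compound 4 (0.16 log units; within the scatter) and it would remain within the scatter. For compound 4 the estimate is 25000 nM with an expected range from 11000 nM to 55000 nM on present data.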

Compound 4, half-maximal cytotoxic concentration: 16400 nM
Estimate against measurement, compound 4: 1.5-fold (0.18 log units) above, within the range that was stated.
By their numbers in this assay, from the lowest: compounds 4, 2 and 3 (each within the scatter of the next, the first and the last beyond it). At a limit, above all of these: compound 1.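

In this assay the step is a 1.1-fold lower number from compound 2 to compound 4 (0.02 log units; within the scatter) and so methoxy in place of hydrogen on the aromatic carbon meta to a fused ring and para to a fused ring gives no readable change. With a 2.0-fold higher number from compound 2 to compound 3 (0.29 log units; within the scatter) beside it, the same replacement now stays within the scatter at two aromatic carbons of the shared core, where a single precedent stood before. Compound 3 at 34100 nM and compound 4 at 16400 nM lie beyond the scatter of each other while each stays within the scatter of compound 2, and this one pair is too little to show that the position of the methoxy matters.

On these data alone, what an amine, a carboxylic acid or a longer alkoxy chain would do on this aromatic carbon remains open, as does the outcome for methoxy on the other carbons of this ring. Compound 1 gives > 100000 nM and this entry is a limit of the assay, not a number: the limit of > 100000 nM in this assay, at which 1 of the 4 values shown sits.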